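The source may hold more compounds than are shown below. What is called first, only, known or untested is meant among the compounds shown, and "the series" means these compounds.

In a functional assay on HL-60 cells (Homo sapiens) for antiproliferative activity, with a stated time of 72 h (on this read-out higher numbers stand for weaker inhibition and lower numbers for stronger inhibition), three compounds have been measured:

- compound 1, `COc1cc(OC)c(C(=O)/C=C/c2ccccc2Cl)c(O)c1CN(C)CCCN(C)C`, gives 11400 nM
- compound 2, `CCN(CC)Cc1c(OC)cc(OC)c(C(=O)/C=C/c2ccccc2Cl)c1O`, gives 30900 nM
- compound 3, `COc1cc(OC)c(C(=O)/C=C/c2ccccc2Cl)c(O)c1CN(C)C`, gives 19200 nM

Compound 3 sits second highest of these three numbers, and both of its neighbours lie within the scatter of it: a 1.6-fold lower number from compound 2 to compound 3 (0.21 log units; within the scatter) and a 1.7-fold higher number from compound 1 to compound 3 (0.23 log units; within the scatter) are each too small to count as real differences. Only a 2.7-fold higher number from compound 1 to compound 2 (0.43 log units; beyond the scatter) is beyond the scatter, and it concerns a change at the amine rather than at the carbon that matters here.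

Compound 4, `COC(=O)CN(C)Cc1c(OC)cc(OC)c(C(=O)/C=C/c2ccccc2Cl)c1O`, is compound 3 with one change: methoxycarbonyl in place of hydrogen on a saturated chain carbon bound to an amine nitrogen. Among the compounds with values here, the closest precedent is the step from compound 1 to compound 3, which changes the group on the same saturated chain carbon bound to an amine nitrogen and stays within the scatter. The changes at the amine itself, between compound 2 and compound 3, likewise stay within the scatter. Within the data shown here, nothing measured so far shows that varying this part of the shared core moves the number much in either direction, so compound 4 is expected to show a 1.1-fold higher number from compound 3 to compound 4 (0.06 log units; within the scatter), a step that need not exceed the scatter. Compound 4 is therefore estimated at 22000 nM, with a range from 8000 nM to 60000 nM.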

Compound 4, half-maximal inhibitory concentration: 400 nM
Compound 4: the middle estimate sits 55-fold (1.74 log units) above what was measured; measured number below the stated range.
By their numbers in this assay, from the lowest: compound 4; then compounds 1, 3 and 2 (each within the scatter of the next, the first and the last beyond it).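

In this assay, within the data shown here, the carbon on this amine proves far more sensitive than the earlier compounds suggested: methoxycarbonyl in place of hydrogen on a saturated chain carbon bound to an amine nitrogen gives a 48-fold lower number from compound 3 to compound 4 (1.68 log units; beyond the scatter) in a series whose other steps had been small. The size of the change depends on what the carbon carries, as swapping 2-(dimethylamino)ethyl for methoxycarbonyl at the same place gives a 29-fold lower number from compound 1 to compound 4 (1.45 log units; beyond the scatter) and replacing the whole diethylamino group with ((methoxycarbonyl)methyl)(methyl)amino gives a 77-fold lower number from compound 2 to compound 4 (1.89 log units; beyond the scatter) on the same shared core, so a change at this amine does not by itself bring the number down, and only the ester-bearing compound 4 stands apart from the others. No available evidence explains this drop.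

The compounds shown leave open whether the methoxycarbonyl group itself is needed, since a carboxylic acid, a primary amide or an ethoxycarbonyl group at the same carbon would test that directly. They also leave open whether a longer chain carrying the methoxycarbonyl, or an ethyl group in place of the methyl on the amine nitrogen, would keep so low a number.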